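The source may report more compounds than this note shows. Statements on the series, on what has been measured and on what is new or still open speak of the compounds shown alone.

Working notes on the series. Two compounds carry numbers in an assay on HEK293 cells for inhibition of Steryl-sulfatase (Homo sapiens), tested at 1 uM; a lower number here means a weaker effect, a higher number a stronger effect of the compound at the concentration tested. Compound 1, `CCN(Cc1ccccc1)c1cccc(C(=O)N2CCc3ccc(OS(N)(=O)=O)cc3C2)c1`, gives 69% in that assay. Compound 2, `NS(=O)(=O)Oc1ccc2c(c1)CN(C(=O)c1cccc(N(Cc3ccccc3)Cc3ccco3)c1)CC2`, gives 90.5%. Among the compounds with values here, the single step between measured compounds, a number 21.5 percentage points higher from compound 1 to compound 2 (beyond the scatter), comes from putting furan-2-yl in place of methyl on a saturated chain carbon bound to a nitrogen on an aromatic ring. Compound 1 therefore stands lowest of the two numbers, with compound 2 the nearest and beyond the scatter.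

Compound 3, `CCN(Cc1ccc(Br)cc1)c1cccc(C(=O)N2CCc3ccc(OS(N)(=O)=O)cc3C2)c1`, is not yet measured. It differs from compound 1 as follows: bromo in place of hydrogen on an aromatic carbon. Within the data shown here, the change turns benzyl into 4-bromobenzyl and leaves the chain carbon that the measured step varied untouched; that step does not bear directly on this one, and no measured pair shows a bromo entering an aromatic carbon. The data give no basis for a step beyond the scatter in this assay. The expected step is a number 1 percentage points higher from compound 1 to compound 3 (within the scatter), essentially nothing beyond the scatter. Compound 3 is estimated at 70%, in the range 55% to 85%.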

Compound 3, a percentage reported as inhibition, at one concentration (the size of the read-out at that concentration, not a potency): 84.5%
Beside the measured number, compound 3's estimate is 14.5 percentage points below it; low and high end bracket the measured number.
By their numbers in this assay, from the lowest: compound 1; then compounds 3 and 2 (each within the scatter of the next).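

In this assay the phenyl ring of the benzyl group proves responsive to substitution: a bromo on an aromatic carbon, para to a large group, gives a number 15.5 percentage points higher from compound 1 to compound 3 (beyond the scatter) with the ethyl group left untouched. The earlier compounds shown here showed a change only at that ethyl group, where furan-2-yl in place of methyl gave a number 21.5 percentage points higher from compound 1 to compound 2 (beyond the scatter) and left the benzyl group as it was, so the benzyl(ethyl)amino group now has two places at which a single change moves the number beyond the scatter. No measurement at hand accounts for the gain from the bromo, so its origin stays unexplained.

The compounds shown contain only one substituent on this phenyl ring, so it remains open whether the step belongs to bromo in particular or would also appear with a chloro, a methoxy, a nitrile or a carboxylic acid in its place. Also open, from the compounds shown here alone, is how the 4-bromobenzyl group and the furan-2-yl change behave when combined in one compound, since the two have so far been seen only separately against compound 1.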